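Replacing the Carboxylic Acid with a Methyl-Oxadiazole Ring

A few compounds are considered here, and "the series" means these few. Any claim that something is new, unique, unknown or untested is made for them only; others in the source may bear on it.

Of the compounds shown here, three sharing one core have been measured in a functional assay for antagonist activity at transient receptor potential cation channel subfamily V member 1 (Rattus norvegicus); a higher number here means a weaker inhibitor, a lower number a stronger inhibitor. Compound 1 `CCCOc1cccnc1-c1ccc(C(=O)Nc2ccc(C(C)(C)C)cc2)cc1` gives 20 nM. Compound 2 `CC(C)(C)c1ccc(NC(=O)c2ccc(-c3ncccc3N(S(C)(=O)=O)S(C)(=O)=O)cc2)cc1` gives 0.4 nM. Compound 3 `CC(C)(C)c1ccc(NC(=O)c2ccc(-c3ncccc3C(=O)O)cc2)cc1` gives 560 nM, the highest of the three numbers and thus the weakest inhibitor: the step of a 28-fold higher number from compound 1 to compound 3 (1.45 log units; beyond the scatter) and the step of a 1400-fold higher number from compound 2 to compound 3 (3.15 log units; beyond the scatter) both lie beyond the scatter. Every change at this one position on the core has moved the number strongly, and the carboxy group has been the worst choice so far.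

Compound 4 `Cc1nnc(-c2cccnc2-c2ccc(C(=O)Nc3ccc(C(C)(C)C)cc3)cc2)o1` is not yet measured. It differs from compound 3 by 5-methyl-1,3,4-oxadiazol-2-yl in place of carboxy on an aromatic carbon. Since the carboxy group left compound 3 as the weakest of the three, and the two other groups seen at this position gave much lower numbers, a large downward step is expected here, likely landing near compound 1 rather than reaching compound 2. In this assay compound 4 is expected to give about 15 nM, within a range of 2 nM to 120 nM. This expectation corresponds to a 37-fold lower number from compound 3 to compound 4 (1.57 log units; beyond the scatter).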

Compound 4, half-maximal inhibitory concentration: 34 nM
Estimate against measurement, compound 4: 2.3-fold (0.36 log units) below; measured number inside the range.
By their numbers in this assay, from the lowest: compound 2; then compounds 1 and 4 (each within the scatter of the next); then compound 3.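

In this assay, a five-membered aromatic ring is accepted at this position: 5-methyl-1,3,4-oxadiazol-2-yl in place of carboxy gives a 16-fold lower number from compound 3 to compound 4 (1.22 log units; beyond the scatter). Against the propoxy group, the change gives a 1.7-fold higher number from compound 1 to compound 4 (0.23 log units; within the scatter), so this ring and the open chain cannot be told apart here, even though the ring brings more heavy atoms. Bis(methylsulfonyl)amino remains well ahead of the ring, as an 85-fold higher number from compound 2 to compound 4 (1.93 log units; beyond the scatter) shows, so the ring matches propoxy but does not reach the best group at this position.

Nothing available explains why these groups rank as they do. From the compounds shown here alone, it remains open whether a simple amine, a single methylsulfonyl group on nitrogen, or the same oxadiazole without its methyl would come closer to compound 2.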